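A few compounds are considered here, and "the series" means these few. Any claim that something is new, unique, unknown or untested is made for them only; others in the source may bear on it.

Measured in an ADME assay on microsomes from liver (Mus musculus) for metabolic stability; a lower number here means slower removal, a higher number faster removal of the compound:

compound 1 `Cn1cc(-c2cc(C(N)=O)ccc2Oc2ccccc2)c2cc[nH]c2c1=O`: 450 mL/min/kg
compound 2 `Cn1cc(-c2cc(S(N)(=O)=O)ccc2Oc2ccccc2)c2cc[nH]c2c1=O`: 517 mL/min/kg
compound 3 `Cn1cc(-c2cc(NS(C)(=O)=O)ccc2Oc2ccccc2C(F)(F)F)c2cc[nH]c2c1=O`: 1350 mL/min/kg

Compound 3 stands highest of the three, and its number lies beyond the scatter from both compound 1 and compound 2. Compound 4 `Cn1cc(-c2cc(NS(C)(=O)=O)ccc2OC2CCC(F)(F)CC2)c2cc[nH]c2c1=O` has not yet been measured in this assay. It departs from compound 3 in one place: 4,4-difluorocyclohexyl in place of 2-(trifluoromethyl)phenyl on an oxygen on an aromatic ring. Read one bond further out, 2-(trifluoromethyl)phenoxy gives way to (4,4-difluorocyclohexyl)oxy.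

Among the measured compounds shown here, the only measured step is a 1.1-fold higher number from compound 1 to compound 2 (0.06 log units; within the scatter), with sulfamoyl in place of carbamoyl on an aromatic carbon. That step lies within the scatter and involves a different change, so it offers only weak guidance. For the measured compounds named here, no measured step shows what happens when the group on this oxygen is replaced. With so little evidence, the expectation rests mainly on the position of compound 3, whose 1350 mL/min/kg is the top of a small set. A lower number is therefore expected for compound 4, but only weakly, and the change may not clear the scatter. The expected step is a 1.7-fold lower number from compound 3 to compound 4 (0.23 log units; within the scatter), a modest estimate held with little confidence. For compound 4 the estimated value is 800 mL/min/kg, with an expected range from 330 mL/min/kg to 1900 mL/min/kg.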

Compound 4, clearance: 717 mL/min/kg
Estimate against measurement, compound 4: 1.1-fold (0.05 log units) above; the range from low to high includes it.
By their numbers in this assay, from the lowest: compounds 1, 2, 4 and 3 (each within the scatter of the next, the first and the last beyond it).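

Among the compounds shown here, the change at this oxygen, 4,4-difluorocyclohexyl in place of 2-(trifluoromethyl)phenyl, is the first replacement of this group that can be read in this assay, and it gives a 1.9-fold lower number from compound 3 to compound 4 (0.27 log units; within the scatter). For the compounds shown here, the earlier step concerned a different place, so this is the first sign that, for this one pair, an aromatic ring of carbon only on this oxygen can be exchanged for a non-aromatic ring of carbon only without the two numbers separating beyond the scatter. None of the information at hand accounts for this result or ties it to any property of either group.

A single pair cannot show whether the same holds for other groups on this oxygen, such as a longer chain, a plain phenyl or a ring that carries an amine. As far as these compounds go, compound 1 and compound 2 differ from compound 3 in more than one place, so the separate contributions of the 2-(trifluoromethyl)phenyl group and of the group on the other aromatic carbon also remain open.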